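A few compounds are considered here, and "the series" means these few. Any claim that something is new, unique, unknown or untested is made for them only; others in the source may bear on it.

Measured so far:
compound 1 `COc1cc(C(=O)N2CCCC2)cc2nc(NCc3cccc(Cl)c3)oc12` — 180 nM
compound 2 `COc1cc(C(=O)N2CCC(O)C(C)C2)cc2nc(NCc3cncc(Cl)c3)oc12` — 7200 nM

In an assay on isolated protein for inhibition of thyroid hormone receptor beta (Homo sapiens), read by fluorescence, with a stated time of 30 min (on this read-out lower numbers stand for stronger inhibition and higher numbers for weaker inhibition), compound 2 gives 7200 nM, the higher of the two numbers; compound 1 gives 180 nM, a gap well beyond the usual scatter. Compound 3 `COc1cc(C(=O)N2CCC(O)C(C)C2)cc2nc(NC3(c4cccc(Cl)c4)CCC3)oc12` differs from compound 2 in one place: 1-(3-chlorophenyl)cyclobutyl in place of (5-chloropyridin-3-yl)methyl on a nitrogen on an aromatic ring. Within the data shown here, no measured pair shows this exact change, so the expectation rests on compound 2 alone, with compound 1 at 180 nM showing that far lower numbers occur. A step from compound 2 toward a lower number, a 4.8-fold lower number from compound 2 to compound 3 (0.68 log units; beyond the scatter), is expected. Compound 3 is estimated at 1500 nM, with a range from 300 nM to 8000 nM.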

Compound 3, half-maximal inhibitory concentration: 8200 nM
Compound 3: the middle estimate sits 5.5-fold (0.74 log units) below what was measured, outside the stated range (above it).
By their numbers in this assay, from the lowest: compound 1; then compounds 2 and 3 (each within the scatter of the next).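

In this assay, placing 1-(3-chlorophenyl)cyclobutyl instead of (5-chloropyridin-3-yl)methyl on the nitrogen gives a 1.1-fold higher number from compound 2 to compound 3 (0.06 log units; within the scatter), so this exchange of groups produces no readable shift. Among these compounds, the swap brings in a four-membered carbon ring and removes the hetero atom from the six-membered aromatic ring, and the single step cannot separate these two alterations, which may have no effect or may offset each other. No measurement available here explains the result.

From the compounds shown here alone, a 1-(5-chloropyridin-3-yl)cyclobutyl group would separate the two alterations, so its effect remains open. Also open, going by these compounds, is how a carboxylic acid in place of the chlorine would read.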